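The source may report more compounds than this note shows. Statements on the series, on what has been measured and on what is new or still open speak of the compounds shown alone.

Measured so far:
Compound 1, `COc1cccc(/C=C/C(=O)c2sc(Nc3ccc(Cl)cc3)nc2C)c1`: in a functional assay on PC-3 cells (Homo sapiens) for cytotoxicity, read by MTT assay (a lower number here means a stronger inhibitor, a higher number a weaker inhibitor), compound 1 gives > 25000 nM, which is a limit of the assay rather than a number.
Compound 2, `Cc1ccccc1Nc1nc(C)c(C(=O)/C=C/c2ccc(Cl)cc2)s1`: in this assay compound 2 gives > 25000 nM, again a limit rather than a number.

Compound 2 therefore stands where every value here stands: the limit of > 25000 nM in this assay, at which 2 of the 2 values shown sit. Compound 3, `Cc1nc(Nc2ccc(Cl)cc2)sc1C(=O)/C=C/c1ccc(Cl)cc1`, differs from compound 2 by 4-chlorophenyl in place of 2-methylphenyl on a nitrogen on an aromatic ring. Because the limit of > 25000 nM in this assay, at which 2 of the 2 values shown sit, already covers compound 1, which carries that same 4-chlorophenyl group on the nitrogen, the expected step from compound 2 to compound 3 is a step that the limit leaves unreadable from compound 2 to compound 3, nothing beyond the usual scatter. Compound 3 is estimated at 30000 nM, ranging from 8000 nM to 100000 nM, and will most likely be reported only as a limit.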

Compound 3, half-maximal inhibitory concentration: > 25000 nM
Compound 3 ended at the assay's limit (the forecaster's own chance of this, stated with the estimate: 75%); the middle value is on the limit's open side.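

No step can be read from compound 1 or compound 2 to compound 3, since each value is a limit and not a number: the limit of > 25000 nM in this assay, at which 3 of the 3 values shown sit. The compounds shown leave open whether any change to these groups would give a measurable value in this assay.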